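Swapping Pyrrole for Oxazole in Compound 1

The source may hold more compounds than are shown below. What is called first, only, known or untested is meant among the compounds shown, and "the series" means these compounds.

Measured compounds in a functional assay on the whole organism for inhibition, with Rattus norvegicus as the target, read by paw edema; on this read-out higher numbers stand for an effect only at larger amounts of compound and lower numbers for an effect already at smaller amounts:
compound 1, `O=C(O)c1cc(-n2cccc2)ccc1O`: 50 mg/kg
compound 2, `O=C(O)c1ccc(-c2ncco2)cc1O`: a limit, > 250 mg/kg
compound 3, `CC(=O)Oc1ccc(-n2cccc2)cc1C(=O)O`: 42 mg/kg

Compound 1 gives 50 mg/kg in this assay. Compound 3 lies within the usual scatter of it, the step being a 1.2-fold lower number from compound 1 to compound 3 (0.08 log units; within the scatter), so the two cannot be told apart. For compound 2 the assay reports only a limit, > 250 mg/kg, and no number.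

The unmeasured compound 4, `O=C(O)c1cc(-c2ncco2)ccc1O`, differs from compound 1 in one place: 1,3-oxazol-2-yl in place of 1H-pyrrol-1-yl on an aromatic carbon. Among the compounds with values here, none of the measured steps covers this exchange; the only measured step, a 1.2-fold lower number from compound 1 to compound 3 (0.08 log units; within the scatter), concerns the acetyl group and stays within the scatter. Compound 2 carries the entering 1,3-oxazol-2-yl group at another place on the core and reached only the limit (the limit of > 250 mg/kg in this assay, at which 1 of the 3 values shown sits), which points towards a higher number, but without a direct comparison the size is uncertain.

Compound 4 is therefore expected to give 120 mg/kg, with a range from 50 mg/kg to 250 mg/kg. This estimate means a step of a 2.4-fold higher number from compound 1 to compound 4 (0.38 log units; beyond the scatter), and a limit rather than a number is plausible.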

Compound 4, dose for half-maximal effect: 100 mg/kg
Estimate against measurement, compound 4: 1.2-fold (0.08 log units) above; the measured number falls inside the stated range.
By their numbers in this assay, from the lowest: compounds 3, 1 and 4 (each within the scatter of the next, the first and the last beyond it). At a limit, above all of these: compound 2.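

At the aromatic carbon meta to the carboxy group and para to the hydroxy group, the exchange gives a 2.0-fold higher number from compound 1 to compound 4 (0.30 log units; within the scatter), so compound 1 and compound 4 cannot be told apart in this assay. This position therefore accepts a five-membered aromatic ring with 2 hetero atoms, joined through carbon, as well as one with 1 hetero atom, joined through nitrogen. The limit of compound 2, which carries the 1,3-oxazol-2-yl group at another place on the core, thus does not describe this position: the limit of > 250 mg/kg in this assay, at which 1 of the 4 values shown sits.

As far as these compounds go, what an amine or a longer alkyl chain would do at this carbon remains open. From the compounds shown here alone, it is also open whether an acetyl group on the hydroxy oxygen of compound 4 would stay within the scatter, as it does on compound 1.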